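A few compounds are considered here, and "the series" means these few. Any claim that something is new, unique, unknown or untested is made for them only; others in the source may bear on it.

Measured compounds:
compound 1, `COc1ccc(/C=C2\CCC/C(=C\c3cccc(OC)c3OC)C2=O)cc1`: 18600 nM
compound 2, `COc1ccc(/C=C2\CCC/C(=C\c3ccccc3Br)C2=O)cc1OC`: 9500 nM

In a functional assay on MCF7 cells (Homo sapiens) for cytotoxicity, read by MTT assay, with a stated time of 72 h (on this read-out higher numbers stand for weaker inhibition and lower numbers for stronger inhibition), compound 2 gives 9500 nM, the lowest of the two numbers, while compound 1 gives 18600 nM; the gap between them lies within the scatter of repeated measurements, so the two compounds cannot be told apart on these data.

Compound 3, `COc1ccc(/C=C2\CCC/C(=C\c3ccc(Cl)cc3Cl)C2=O)cc1OC`, has not yet been measured in this assay. It differs from compound 2 in one place: 2,4-dichlorophenyl in place of 2-bromophenyl on a double-bonded chain carbon bound to a double-bonded ring carbon. Among the compounds with values here, no step between measured compounds is available for this kind of change, so nothing on record shows how the read-out responds to it.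

Compound 3 is therefore expected to stay close to compound 2, and the step of a 1.1-fold lower number from compound 2 to compound 3 (0.02 log units; within the scatter) is expected to be none beyond the scatter. The estimate for compound 3 is 9000 nM, with a range from 3000 nM to 27000 nM.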

Compound 3, half-maximal inhibitory concentration: 16200 nM
The estimate for compound 3 lay 1.8-fold (0.26 log units) below the measured number, within the range that was stated.
By their numbers in this assay, from the lowest: compounds 2, 3 and 1 (each within the scatter of the next).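

In this assay, within the data shown here, the exchange of 2-bromophenyl for 2,4-dichlorophenyl on a double-bonded chain carbon bound to a double-bonded ring carbon gives a 1.7-fold higher number from compound 2 to compound 3 (0.23 log units; within the scatter), the first step on record at this place. This read-out therefore does not tell the two groups apart, even though the exchange alters both the halogen and the number of halogen atoms on the ring. Nothing available accounts for this result or links it to any property of either group.

On these data alone, whether a single chlorine alone would behave like the bromine remains open, and the two halogen changes cannot be separated from this one step. Also open, as far as these compounds go, is whether a phenyl ring carrying a dimethylamino group or a carboxylic acid at this place would move the number beyond the scatter.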